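The compounds below may be only part of what the source reports. "The series", "measured", "known", "first", "only" and "open" are said of these compounds alone.

Working notes on the series. In a functional assay on HCT-116 cells (Homo sapiens) for antiproliferative activity, read by MTT assay, with a stated time of 48 h (a lower number here means a stronger inhibitor, a higher number a weaker inhibitor), compound 1 `COc1ccc(/C=C/C=C\c2cc(OC)c(OC)c(OC)c2)cc1O` gives 42.3 nM, compound 2 `CCOc1cc(-c2ccc3[nH]ccc3c2)cn2c(-c3cc(OC)c(OC)c(OC)c3)nnc12` gives 374 nM and compound 3 `COc1cc(-c2nnc3c(OC)cc(-c4ccc5[nH]ccc5c4)cn23)cc(OC)c1OC` gives 108 nM. Compound 3 is therefore the second highest of the three numbers, with compound 1 lower and compound 2 higher, and both gaps lie beyond the scatter.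

Compound 4 `COc1cc(-c2nnc3c(OC(C)C)cc(-c4ccc5[nH]ccc5c4)cn23)cc(OC)c1OC` differs from compound 3 in one place: isopropyl in place of methyl on an oxygen on an aromatic ring. This is methoxy to isopropoxy, with isopropyl in place of methyl on an oxygen on an aromatic ring.

Within the data shown here, only one measured step bears on this change, the loss of a methyl from the saturated chain on such an oxygen. It is modest and beyond the scatter: a 3.5-fold lower number from compound 2 to compound 3 (0.54 log units; beyond the scatter). Read in reverse, that single pair points to a higher number in this assay, of similar or somewhat larger size, though it is thin support. The expected move is a 3.9-fold higher number from compound 3 to compound 4 (0.59 log units; beyond the scatter). Compound 4 is estimated at 420 nM, with an expected range of 160 nM to 1100 nM.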

Compound 4, half-maximal inhibitory concentration: 939 nM
Compound 4: middle estimate off by 2.2-fold (0.35 log units), on the low side; low and high end bracket the measured number.
By their numbers in this assay, from the lowest: compound 1; then compound 3; then compound 2; then compound 4.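

In this assay the earlier pair showed only that ethyl on this oxygen gives a higher number than methyl; compound 4 shows that the rise continues with isopropyl. Among these compounds, the full change from methoxy to isopropoxy gives an 8.7-fold higher number from compound 3 to compound 4 (0.94 log units; beyond the scatter) and is the largest step at this position so far, while the added methyl alone, going from the ethyl chain to isopropyl, still gives a 2.5-fold higher number from compound 2 to compound 4 (0.40 log units; beyond the scatter) as a further rise beyond the scatter. Among compounds 3, 2 and 4 the number thus climbs with each carbon added to the chain on this oxygen, none of the three goes against that order, and nothing available explains it.

The compounds shown leave open whether branching or chain size drives the last rise, which a straight propyl chain on this oxygen would help to separate. Also open, from the compounds shown here alone, is how a free hydroxy group or an amine-bearing chain would read here.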